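This account rests on a few compounds, and the source may have more. Where it says the series, first, only, none or still open, it means among the compounds named here.

Compound 1 `CCc1cc(C(=O)OCO[P@@]2(=O)OCC(C)(C)[C@H](C(=O)NCCC(=O)OC)O2)n(C)n1` is one of three compounds that have so far been tested in an ADME assay on blood (Homo sapiens) for pharmacokinetics; on this read-out higher numbers stand for a longer-lived compound and lower numbers for a shorter-lived compound. In this assay compound 1 gives >= 0.97 h, which is a limit of the assay rather than an exact number. So where compound 1 stands is known only as a boundary, and one of the other two values is a boundary as well. Compound 2 `CC(C)(C)C(=O)OCO[P@@]1(=O)OCC(C)(C)[C@H](C(=O)NCCC(=O)OCCc2ccccn2)O1` gives < 0.16 h in this assay, again a limit of the assay. Compound 3 `COC(=O)CCNC(=O)[C@@H]1O[P@](=O)(OCOC(=O)c2scnc2C(C)(C)C)OCC1(C)C` gives 0.44 h in this assay, a plain number. The three values therefore reach from the limit of < 0.16 h in this assay, at which 1 of the 3 values shown sits, up to the limit of >= 0.97 h in this assay, at which 1 of the 3 values shown sits. No pair among these three compounds differs in just one place, so no single measured step is available.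

Compound 4 `COC(=O)CCNC(=O)[C@@H]1O[P@@](=O)(OCOC(=O)c2scnc2C)OCC1(C)C` has not yet been measured. It differs from compound 1 in one place: 4-methyl-1,3-thiazol-5-yl in place of 3-ethyl-1-methyl-1H-pyrazol-5-yl on a carbonyl carbon. The ester group on the carbonyl carbon is thus swapped from one five-membered aromatic ring to another, with fewer heavy atoms. Compound 4 is expected to have a shorter half-life than compound 1, a step of an at least 3.2-fold lower number from compound 1 to compound 4 (0.50 log units; beyond the scatter) that would lie beyond the usual scatter. That expectation leans on compound 3, which gives 0.44 h and so sits well short of the upper boundary. Compound 4 is estimated at 0.3 h, with a likely range from 0.12 h to 0.8 h.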

Compound 4, half-life: > 1 h
Compound 4 was reported as a limit; the forecaster's own chance of this, stated with the estimate: 25%; middle value at least 3.3-fold (0.52 log units) away from the limit.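

In this assay compound 1 and compound 4 are both reported only as limits, so the step between them cannot be read. The compounds shown leave open whether 4-methyl-1,3-thiazol-5-yl in place of 3-ethyl-1-methyl-1H-pyrazol-5-yl on a carbonyl carbon changes the half-life at all, and in which direction.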